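A few compounds are considered here, and "the series" means these few. Any claim that something is new, unique, unknown or untested is made for them only; others in the source may bear on it.

Compound 1 `CCc1nc(C(C)C)c2n1CCN([C@@H](C(=O)NC)c1ccccc1)C2CCc1ccc(C(F)(F)F)cc1`: 10000 nM
Compound 2 `CCc1nc(I)c2n1CCN([C@@H](C(=O)NC)c1ccccc1)C2CCc1ccc(C(F)(F)F)cc1`: 717 nM

For the measured compounds named here, in a functional assay on CHO cells for antagonist activity at Orexin/Hypocretin receptor type 1 (Homo sapiens), read by FLIPR and calcium flux (a lower number here means a stronger inhibitor, a higher number a weaker inhibitor), compound 2 gives 717 nM, the lower of the two numbers, and the only measured step, a 14-fold lower number from compound 1 to compound 2 (1.14 log units; beyond the scatter), is a large one. Compound 3 `CCc1nc(OC)c2n1CCN([C@@H](C(=O)NC)c1ccccc1)C2CCc1ccc(C(F)(F)F)cc1` differs from compound 2 by methoxy in place of iodo on an aromatic carbon. No measured step swaps iodo for methoxy, so the single step shown bears on it only loosely, and a moderate rise in the number seems plausible but uncertain. Compound 3 is therefore estimated at 3000 nM, within 700 nM to 10000 nM. This estimate for compound 3 means an expected step of a 4.2-fold higher number from compound 2 to compound 3 (0.62 log units; beyond the scatter).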

Compound 3, half-maximal inhibitory concentration: 134 nM
Compound 3: the middle estimate sits 22-fold (1.35 log units) above what was measured; the whole stated range lies above it.
By their numbers in this assay, from the lowest: compound 3; then compound 2; then compound 1.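

In this assay, methoxy on this aromatic carbon gives a 5.4-fold lower number from compound 2 to compound 3 (0.73 log units; beyond the scatter), and set against isopropyl it gives a 75-fold lower number from compound 1 to compound 3 (1.87 log units; beyond the scatter), so this position can hold a group better than either earlier one. Methoxy has more heavy atoms than iodo yet gives the lower number, so a higher heavy-atom count here does not by itself cost activity. Nothing measured here explains this gain.

Going by these compounds, whether the gain follows the oxygen, which brings the one hydrogen-bond acceptor, remains open. A hydroxyl, an ethoxy or an amine on this carbon would help to separate these possibilities.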